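The source may report more compounds than this note shows. Statements on the series, on what has been measured and on what is new or still open speak of the compounds shown alone.

Measured in an assay on isolated protein for inhibition of glutathione S-transferase P (Homo sapiens), with a stated time of 10 min; on this read-out higher numbers stand for weaker inhibition and lower numbers for stronger inhibition:
compound 1 `O=C(CCC(=O)OCCCCCCSc1ccc([N+](=O)[O-])c2nonc12)Nc1ccccc1F`, 9890 nM
compound 2 `COc1ccccc1NC(=O)CCC(=O)OCCCCCCSc1ccc([N+](=O)[O-])c2nonc12`, 4050 nM
compound 3 `Cc1ccc(NC(=O)CCC(=O)OCCCCCCSc2ccc([N+](=O)[O-])c3nonc23)cc1`, 6800 nM

For the measured compounds named here, compound 2 gives the lowest of the three numbers in this assay; its gap to compound 3 lies within the scatter, and the only step beyond the scatter is a 2.4-fold lower number from compound 1 to compound 2 (0.39 log units; beyond the scatter). Compound 4 `O=C(CCC(=O)N1CCOCC1)OCCCCCCSc1ccc([N+](=O)[O-])c2nonc12` is the unmeasured member, and it differs from compound 2 by morpholin-4-yl in place of (2-methoxyphenyl)amino on a carbonyl carbon. Going by the values given here, none of the measured steps bears directly on this change: a 2.4-fold lower number from compound 1 to compound 2 (0.39 log units; beyond the scatter), a 1.5-fold lower number from compound 1 to compound 3 (0.16 log units; within the scatter) and a 1.7-fold higher number from compound 2 to compound 3 (0.23 log units; within the scatter) all vary only the substituent on the aromatic ring that here leaves, and all were small. A modest step toward a higher number is therefore expected for compound 4, a 2.2-fold higher number from compound 2 to compound 4 (0.35 log units; beyond the scatter). Compound 4 is estimated at 9000 nM, within a range from 3500 nM to 25000 nM.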

Compound 4, half-maximal inhibitory concentration: 330 nM
The estimate for compound 4 lay 27-fold (1.44 log units) above the measured number; the measured number lies below the stated range.
By their numbers in this assay, from the lowest: compound 4; then compounds 2, 3 and 1 (each within the scatter of the next, the first and the last beyond it).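

Morpholin-4-yl in place of the substituted phenylamino groups on this carbonyl carbon gives (a 12-fold lower number from compound 2 to compound 4 (1.09 log units; beyond the scatter)), (a 21-fold lower number from compound 3 to compound 4 (1.31 log units; beyond the scatter)) and (a 30-fold lower number from compound 1 to compound 4 (1.48 log units; beyond the scatter)). The group on this carbonyl carbon therefore moves the number far more than the aromatic substituents varied among compound 1, compound 2 and compound 3 did. Nothing available explains this shift.

The change removes the aromatic ring and the amide hydrogen together, and the compounds shown do not separate the two. From the compounds shown here alone, whether piperidin-1-yl or dimethylamino on this carbonyl carbon would give a similarly low number remains open.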